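Bromo for Fluoro in a Cytotoxicity Series

The source may hold more compounds than are shown below. What is called first, only, known or untested is meant among the compounds shown, and "the series" means these compounds.

Three compounds sharing one core have been run in an ADME assay on Huh-7 cells (Homo sapiens) for cytotoxicity, with a stated time of 3 days; on this read-out lower numbers stand for higher toxicity in this test and higher numbers for lower toxicity in this test. Compound 1 `COc1cccc(NC(=O)c2c(NO)cc(-c3ccccc3)oc2=O)c1` gives only the limit of > 20000 nM in this assay, not a number. Compound 2 `O=C(Nc1cc([N+](=O)[O-])ccc1O)c1c(NO)cc(-c2ccccc2)oc1=O` likewise yields only the limit of > 20000 nM. Compound 3 `O=C(Nc1ccc(F)cc1)c1c(NO)cc(-c2cccs2)oc1=O` also returns the limit of > 20000 nM. Compound 3 therefore stands where all values shown stand, at the limit of > 20000 nM in this assay, at which 3 of the 3 values shown sit. Compound 4 `O=C(Nc1ccc(Br)cc1)c1c(NO)cc(-c2cccs2)oc1=O` differs from compound 3 by bromo in place of fluoro on an aromatic carbon. Going by the values given here, no step between measured compounds exists, and every read-out is a limit, so no change beyond the scatter is expected. Compound 4 is estimated at 25000 nM, between 10000 nM and 60000 nM. The step that the limit leaves unreadable from compound 3 to compound 4 is expected to lie within the scatter.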

Compound 4, half-maximal cytotoxic concentration: > 20000 nM
Compound 4 ended at the assay's limit; the forecaster's own chance of this, stated with the estimate: 85%; the middle value lies beyond the limit too.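

Going by these compounds alone, compound 3 and compound 4 both stand at a limit and not at a number, so no step from fluoro to bromo can be read: the limit of > 20000 nM in this assay, at which 4 of the 4 values shown sit.

The compounds shown leave open at what concentration any of them turns cytotoxic, and whether bromo and fluoro would then differ.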